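Growing the side chain from isobutyl to 2-methylbutyl

The source may report more compounds than this note shows. Statements on the series, on what has been measured and on what is new or still open speak of the compounds shown alone.

Compound 1, `CCC(CC)Cn1c(Cc2cc(OC)c(OC)c(OC)c2)nc2c(N)ncnc21`: in a functional assay on MCF7 cells (Homo sapiens) for antiproliferative activity (on this read-out higher numbers stand for weaker inhibition and lower numbers for stronger inhibition), compound 1 gives 158000 nM.
Compound 2, `COc1cc(Cc2nc3c(N)ncnc3n2CC(C)C)cc(OC)c1OC`: in this assay compound 2 gives 97700 nM.

Compound 2 and compound 1 sit within the scatter of each other, so neither can be placed above the other. Compound 3, `CCC(C)Cn1c(Cc2cc(OC)c(OC)c(OC)c2)nc2c(N)ncnc21`, is not yet measured; it differs from compound 2 by methyl in place of hydrogen on a saturated chain carbon, three bonds along the chain from an aromatic nitrogen. Among the compounds with values here, the one measured step on this chain, a 1.6-fold lower number from compound 1 to compound 2 (0.21 log units; within the scatter), stayed within the scatter, and compound 3 carries a branched chain of a size between those of compound 1 and compound 2. In this assay no step beyond the scatter is therefore expected. For compound 3 the estimated value is 110000 nM, with an expected range from 55000 nM to 220000 nM. That estimate means an expected step of a 1.1-fold higher number from compound 2 to compound 3 (0.05 log units; within the scatter).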

Compound 3, half-maximal inhibitory concentration: 61700 nM
For compound 3 the middle estimate is 1.8-fold (0.25 log units) above the measured one; the range from low to high includes it.
By their numbers in this assay, from the lowest: compounds 3, 2 and 1 (each within the scatter of the next, the first and the last beyond it).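

In this assay, methyl in place of hydrogen gives a 1.6-fold lower number from compound 2 to compound 3 (0.20 log units; within the scatter) and so cannot separate these two chains at this position. Hydrogen in place of methyl at the same place gives a 2.6-fold lower number from compound 1 to compound 3 (0.41 log units; beyond the scatter) and is the first step on this chain beyond the scatter, though a modest one. Nothing measured here explains why that single change registers.

Going by these compounds, it remains open whether a longer straight chain, or an amine or a carboxylic acid on the chain, would move the number further.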